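Pyridin-4-yl to 3-hydroxyphenyl in the series

This account rests on a few compounds, and the source may have more. Where it says the series, first, only, none or still open, it means among the compounds named here.

In a functional assay on DU-145 cells (Homo sapiens) for cytotoxicity, read by ELISA, with a stated time of 2 days (a higher number here means a weaker inhibitor, a lower number a stronger inhibitor), compound 1 (`Oc1cccc(-c2cc(-c3ccccc3)cc(-c3cccs3)n2)c1`) gives 18900 nM and compound 2 (`Oc1cccc(-c2cc(-c3ccccc3)cc(-c3ccncc3)n2)c1`) gives 19200 nM so compound 2 stands level with compound 1 within the scatter. Compound 3 (`Oc1cccc(-c2cc(-c3ccccc3)cc(-c3cccc(O)c3)n2)c1`) has 3-hydroxyphenyl in place of pyridin-4-yl next to the ring nitrogen (3-hydroxyphenyl in place of pyridin-4-yl on an aromatic carbon). For the measured compounds named here, the only measured step bearing on this is a 1.0-fold higher number from compound 1 to compound 2 (0.01 log units; within the scatter) at that same place, and no measured step covers a carbon-only ring bearing a hydroxyl. No step beyond the scatter is therefore expected in this assay and the estimated step of a 1.3-fold lower number from compound 2 to compound 3 (0.11 log units; within the scatter) stays small. For compound 3 the estimate is 15000 nM with 5000 nM to 40000 nM as the expected range.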

Compound 3, half-maximal inhibitory concentration: 24900 nM
The estimate for compound 3 lay 1.7-fold (0.22 log units) below the measured number, within the range that was stated.
By their numbers in this assay, from the lowest: compounds 1, 2 and 3 (each within the scatter of the next).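

In this assay, the carbon-only 3-hydroxyphenyl ring, which adds a hydrogen-bond donor, now stands next to the ring nitrogen with no change beyond the scatter, either from pyridin-4-yl (a 1.3-fold higher number from compound 2 to compound 3 (0.11 log units; within the scatter)) or from thiophen-2-yl (a 1.3-fold higher number from compound 1 to compound 3 (0.12 log units; within the scatter)). All three aromatic rings at this position therefore read level. Nothing available explains this flat result.

Going by these compounds, whether an amine, a carboxylic acid or a longer chain at this position would give a step beyond the scatter remains open. On these data alone, the effect of changing the phenyl group on the shared core also remains open.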